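Working notes: from compound 2 to compound 3

The source may hold more compounds than are shown below. What is called first, only, known or untested is meant among the compounds shown, and "the series" means these compounds.

compound 1 `O=c1ccoc2cc(OCc3cn(Cc4ccc(Cl)cc4Cl)nn3)ccc12`: 5260 nM
compound 2 `O=c1ccoc2cc(OCc3cn(Cc4ccc(F)cc4)nn3)ccc12`: > 100000 nM, a limit of the assay

Both entries come from a functional assay on A549 cells (Homo sapiens) for cytotoxicity, read by MTT assay, with a stated time of 48 h; a lower number here means a stronger inhibitor, a higher number a weaker inhibitor. Compound 2 has no number here, only a limit: the limit of > 100000 nM in this assay, at which 1 of the 2 values shown sits.

The next compound is compound 3 `O=c1ccoc2cc(OCc3cn(Cc4ccccc4F)nn3)ccc12`, and the change is 2-fluorophenyl in place of 4-fluorophenyl on a saturated chain carbon bound to an aromatic nitrogen. In words, 2-fluorophenyl stands in place of 4-fluorophenyl on a saturated chain carbon bound to an aromatic nitrogen. The two have the same atoms, joined differently.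

Among the measured compounds shown here, one measured step bears on this place: an at least 19-fold higher number from compound 1 to compound 2 (1.27 log units; beyond the scatter), which is large and beyond the scatter. That step replaced 2,4-dichlorophenyl, so it shows that this place can matter in this assay, but it does not compare the two fluorophenyl groups. Given an at least 19-fold higher number from compound 1 to compound 2 (1.27 log units; beyond the scatter), compound 3, which keeps a fluorophenyl group, is expected to remain weak. Any measurable step is expected to be modest and towards a lower number, and another limit is quite possible.

The estimated step runs an at least 2.0-fold lower number from compound 2 to compound 3 (0.30 log units; that floor lies within the scatter). For compound 3 the estimated value is 50000 nM, with an expected range of 12000 nM to 100000 nM.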

Compound 3, half-maximal inhibitory concentration: 10800 nM
Compound 3: the middle estimate sits 4.6-fold (0.67 log units) above what was measured, outside the stated range (below it).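

In this assay, 2-fluorophenyl in place of 4-fluorophenyl on a saturated chain carbon bound to an aromatic nitrogen gives an at least 9.2-fold lower number from compound 2 to compound 3 (0.96 log units; beyond the scatter), so a change in where the fluorine sits, with the same atoms, is enough to move the series from a limit to a measurable value. Compound 2 carries a limit of the assay and not a number, so the size of this step is a floor only: the limit of > 100000 nM in this assay, at which 1 of the 3 values shown sits.

The other new step, a 2.1-fold higher number from compound 1 to compound 3 (0.31 log units; beyond the scatter), is much smaller than an at least 19-fold higher number from compound 1 to compound 2 (1.27 log units; beyond the scatter), so among these three compounds the groups that give a number are 2,4-dichlorophenyl and 2-fluorophenyl, while 4-fluorophenyl gives only a limit.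

Compound 1 and compound 3 differ in both the kind and the number of halogens, so the compounds shown do not separate these two contributions to the modest step between them; 2-chlorophenyl or 4-chlorophenyl would bear on this directly. Also open, from the compounds shown here alone, is whether the trend extends to 3-fluorophenyl, to a non-halogen group such as 2-methoxyphenyl, or to a longer chain between the aromatic nitrogen and the phenyl ring.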